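A few compounds are considered here, and "the series" means these few. Any claim that something is new, unique, unknown or untested is made for them only; others in the source may bear on it.

Measured so far in an assay on NIH3T3 cells for binding affinity to melatonin receptor type 1B (Homo sapiens); on this read-out lower numbers stand for stronger inhibition and higher numbers for weaker inhibition: compound 1 `CC(C)C(=O)NC[C@@H]1CC1c1cccc2oc(CCCCc3ccccc3)cc12` gives 54 nM; compound 2 `O=C(NC[C@@H]1CC1c1cccc2oc(CCCCc3ccccc3)cc12)C1CC1` gives 33 nM; compound 3 `CC(=O)NCCCc1cccc2oc(CCCCc3ccccc3)cc12` gives 127 nM.

Compound 3 stands highest of the three numbers. Compound 1 is nearest to it, and the two values stand beyond the scatter of each other; compound 2 is furthest from compound 3, again beyond the scatter. Compounds 1 and 2 share a core that differs from that of compound 3 in the linker between the core and the amide nitrogen, so their gap to compound 3 does not isolate any single change.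

Compound 4 `CCNC(=O)NCCCc1cccc2oc(CCCCc3ccccc3)cc12` differs from compound 3 by ethylamino in place of methyl on a carbonyl carbon. Going by the values given here, the only measured step at the same position, a 1.6-fold lower number from compound 1 to compound 2 (0.21 log units; within the scatter), swaps one alkyl for another and lies within the scatter; it says nothing directly about an alkyl being replaced by an amino group, and it sits on a different core. Among the compounds with values here, no measured step therefore bears closely on the change. The expectation for compound 4 is accordingly a step of about a 1.2-fold lower number from compound 3 to compound 4 (0.06 log units; within the scatter) in this assay, not beyond the scatter in either direction. Compound 4 is estimated at 110 nM, with a range from 40 nM to 300 nM.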

Compound 4, inhibition constant: 52 nM
Compound 4: middle estimate off by 2.1-fold (0.33 log units), on the high side; measured number inside the range.
By their numbers in this assay, from the lowest: compounds 2, 4 and 1 (each within the scatter of the next); then compound 3.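

In this assay, the step of a 2.4-fold lower number from compound 3 to compound 4 (0.39 log units; beyond the scatter) shows that this carbonyl carbon, whose other neighbour is an amide-type nitrogen, accepts ethylamino in place of methyl with a gain that lies beyond the scatter. Going by these compounds alone, the only earlier step at a carbonyl carbon, a 1.6-fold lower number from compound 1 to compound 2 (0.21 log units; within the scatter), stayed within the scatter and exchanged one alkyl group for another, so the change from acetamido to (ethylcarbamoyl)amino is the first at this place to move the number measurably. No measurement on hand gives a reason for this step.

As far as these compounds go, the step adds both carbon and a nitrogen bearing a hydrogen-bond donor, so it remains open whether propyl, with no nitrogen, or methylamino, with a shorter chain, would give the same gain. From the compounds shown here alone, it is also open whether ethylamino would produce a similar step on the core of compound 1.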